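The compounds below may be only part of what the source reports. "The series", "measured", "known", "first", "only" and "open" are said of these compounds alone.

Compound 1, `CC1(C)Cc2c(sc(NC(=O)c3ccccc3O)c2C(N)=O)C(C)(C)O1`, in an assay on cells for positive allosteric modulation of Cystic fibrosis transmembrane conductance regulator variant F508del (Homo sapiens), with stated times of 10 min and 7 s, in the presence of a further agent that is not named here (a higher number here means that more compound is needed for the effect, a lower number that less compound is needed), gives 4 nM.
Compound 2, `CC1(C)Cc2c(sc(NC(=O)Cc3ccn[nH]3)c2C(N)=O)C(C)(C)O1`, gives 136 nM.
Compound 3, `CC1(C)Cc2c(sc(NC(=O)C3(O)CC3)c2C(N)=O)C(C)(C)O1`, gives 23 nM.

Compound 3 stands second of the three numbers: the step of a 5.8-fold higher number from compound 1 to compound 3 (0.76 log units; beyond the scatter) is modest, and the step of a 5.9-fold lower number from compound 2 to compound 3 (0.77 log units; beyond the scatter) is modest in the other direction, so compound 3 sits between the other two, separated from each beyond the scatter. Compound 4, `CC1(C)Cc2c(sc(NC(=O)C(C)(C)O)c2C(N)=O)C(C)(C)O1`, has not yet been measured. It differs from compound 3 by 1-hydroxy-1-methylethyl in place of 1-hydroxycyclopropyl on a carbonyl carbon. Among the compounds with values here, no measured step exchanges one small hydroxy-bearing group for another of this kind; the steps from compound 1 and from compound 2 to compound 3 only show that the group on the carbonyl carbon can shift the number by a modest to large amount. Compound 4 is therefore expected to stay near compound 3, the estimated step being a 1.5-fold higher number from compound 3 to compound 4 (0.18 log units; within the scatter), a small move toward a higher number. The estimate for compound 4 is 35 nM, with a range from 12 nM to 110 nM.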

Compound 4, half-maximal effective concentration: 16 nM
Estimate against measurement, compound 4: 2.2-fold (0.34 log units) above; the measured number falls inside the stated range.
By their numbers in this assay, from the lowest: compound 1; then compounds 4 and 3 (each within the scatter of the next); then compound 2.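

In this assay the three-membered ring of 1-hydroxycyclopropyl can give way to the open 1-hydroxy-1-methylethyl, with a 1.4-fold lower number from compound 3 to compound 4 (0.16 log units; within the scatter) as the step. The open group also stands well clear of the pyrazole-bearing group, with an 8.5-fold lower number from compound 2 to compound 4 (0.93 log units; beyond the scatter), yet does not reach the 2-hydroxyphenyl group, with a 4.0-fold higher number from compound 1 to compound 4 (0.60 log units; beyond the scatter). Nothing measured here explains this order. As far as these compounds go, it remains open whether the hydroxy group itself matters, as an amine in its place, in 1-aminocyclopropyl, would show. A longer chain, as in 1-ethyl-1-hydroxypropyl, is also untested in these compounds.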